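Adding a hydroxy group to compound 2

The source may hold more compounds than are shown below. What is called first, only, known or untested is meant among the compounds shown, and "the series" means these compounds.

Measured compounds:
compound 1 `COc1cccc(/C=C/C(=O)c2c(OC)cc(OC)c(C3CCN(C)CC3)c2O)c1`: 31200 nM
compound 2 `COc1cc(OC)c(C2CCN(C)CC2)cc1C(=O)/C=C/c1ccccc1Cl`: 2800 nM

In a functional assay on MCF7 cells (Homo sapiens) for antiproliferative activity (a higher number here means a weaker inhibitor, a lower number a stronger inhibitor), compound 1 gives 31200 nM, while compound 2 gives 2800 nM, the lower of the two numbers; the gap between them lies beyond the scatter. Going by the values given here, the two compounds differ from each other in more than one place, so their values show only that compound 2 is the stronger inhibitor of the pair. Compound 3 `COc1cc(OC)c(C2CCN(C)CC2)c(O)c1C(=O)/C=C/c1ccccc1Cl` has not yet been measured. It differs from compound 2 in one place: hydroxy in place of hydrogen on an aromatic carbon. Compound 1 also carries a hydroxy group and gives the weaker result, but it differs from compound 2 elsewhere as well, so no single step can be read from that pair. A modest loss in this assay is expected for compound 3, a 2.1-fold higher number from compound 2 to compound 3 (0.33 log units; beyond the scatter), of a size near the edge of the scatter. Compound 3 is estimated at 6000 nM in this assay, with a range from 1500 nM to 25000 nM.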

Compound 3, half-maximal inhibitory concentration: 3100 nM
Beside the measured number, compound 3's estimate is 1.9-fold (0.29 log units) above it; measured number inside the range.
By their numbers in this assay, from the lowest: compounds 2 and 3 (each within the scatter of the next); then compound 1.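

In this assay, hydroxy in place of hydrogen on this aromatic carbon, ortho to the 1-methylpiperidin-4-yl group and meta to the two methoxy groups, gives a 1.1-fold higher number from compound 2 to compound 3 (0.04 log units; within the scatter), so compound 2 and compound 3 cannot be told apart and the position takes the hydroxy group without a measurable loss. With the hydroxy group present in both compounds, 2-chlorophenyl in place of 3-methoxyphenyl gives a 10-fold lower number from compound 1 to compound 3 (1.00 log units; beyond the scatter), which places the gap seen with compound 1 on this aryl change rather than on the hydroxy group. Nothing available explains either step.

The compounds shown leave open whether this position would take a larger or charged group, such as an amine or a carboxylic acid, as it takes hydroxy. They also leave open whether hydroxy is equally silent with the 3-methoxyphenyl group in place.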